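Ring size and a methyl at the amine: cytotoxicity

The source may report more compounds than this note shows. Statements on the series, on what has been measured and on what is new or still open speak of the compounds shown alone.

Of the compounds shown here, three sharing one core have been tested in a functional assay on A549 cells (Homo sapiens) for cytotoxicity, read by WST assay, with a stated time of 72 h; a lower number here means a stronger inhibitor, a higher number a weaker inhibitor. Compound 1 `CCN(CC)CCCOc1cc2ncnc(Nc3nc4ccc(C(=O)Nc5c(C)cccc5C)cc4s3)c2cc1OC` gives only a limit of the assay, > 100000 nM, and no number. Compound 2 `COc1cc2c(Nc3nc4ccc(C(=O)Nc5c(C)cc(C)cc5C)cc4s3)ncnc2cc1OCCCN1CCCCC1` gives 10300 nM. Among the compounds with values here, compound 3 `COc1cc2c(Nc3nc4ccc(C(=O)Nc5c(C)cc(C)cc5C)cc4s3)ncnc2cc1OCCCN1CCCC1` gives 8900 nM; together with compound 2 it supplies the only two numbers here, and the two sit within the scatter of one another.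

Compound 4 `COc1cc2c(Nc3nc4ccc(C(=O)Nc5c(C)cc(C)cc5C)cc4s3)ncnc2cc1OCCCN1CCCCC1C` has not been measured. It differs from compound 3 in one place: 2-methylpiperidin-1-yl in place of pyrrolidin-1-yl on a saturated chain carbon, three bonds along the chain from an oxygen on an aromatic ring. Within the data shown here, the one measured step that touches this part of the molecule is a 1.2-fold lower number from compound 2 to compound 3 (0.06 log units; within the scatter). That step is small, and the change now made moves the ring back toward the six-membered one of compound 2 while adding a methyl group to it. Among the measured compounds shown here, no measured pair speaks to such a methyl, so the expectation rests on the ring change alone.

Compound 4 is therefore expected to give 9500 nM, with a range from 4000 nM to 25000 nM. The step of a 1.1-fold higher number from compound 3 to compound 4 (0.03 log units; within the scatter) is expected to stay within the scatter.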

Compound 4, half-maximal inhibitory concentration: 5800 nM
Estimate against measurement, compound 4: 1.6-fold (0.21 log units) above, within the range that was stated.
By their numbers in this assay, from the lowest: compounds 4, 3 and 2 (each within the scatter of the next). At a limit, above all of these: compound 1.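

Within the data shown here, the earlier compounds compared only two unsubstituted rings at this place on the chain, whereas the change to 2-methylpiperidin-1-yl in this assay brings a ring with a methyl on it and gives a 1.5-fold lower number from compound 3 to compound 4 (0.19 log units; within the scatter) and no step beyond the usual spread. Among these compounds, the same compound also provides the first direct reading of the methyl itself: methyl in place of hydrogen on a saturated ring carbon gives a 1.8-fold lower number from compound 2 to compound 4 (0.25 log units; within the scatter) and again stays inside the spread. Neither the larger group nor the added methyl therefore separates these compounds in cytotoxicity.

As far as these compounds go, whether a ring with a second hetero atom, such as morpholine, or a methyl elsewhere on the piperidine ring would also leave the number in place remains open. Nothing shown gives a cause for these numbers.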